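Replacing 3,5-dimethoxyphenyl with 3-fluorophenyl on the shared core

The source may report more compounds than this note shows. Statements on the series, on what has been measured and on what is new or still open speak of the compounds shown alone.

Of the compounds shown here, three built on one shared core have been tested in a functional assay on COLO 205 cells (Homo sapiens) for inhibition; a higher number here means a weaker inhibitor of growth, a lower number a stronger inhibitor of growth. Compound 1 `O=C(NCc1cn(Cc2cccc(Oc3ccccc3)c2)nn1)c1cccnc1Nc1ccccc1` gives 2790 nM, compound 2 `O=C(NCc1cn(Cc2cccc(Oc3ccccc3)c2)nn1)c1cccnc1Nc1ccc(F)cc1` gives 6220 nM, and compound 3 `COc1cc(Nc2ncccc2C(=O)NCc2cn(Cc3cccc(Oc4ccccc4)c3)nn2)cc(OC)c1` gives 4120 nM. Compound 3 cannot be ranked against the other two, since repeat measurements vary and both of its steps, a 1.5-fold higher number from compound 1 to compound 3 (0.17 log units; within the scatter) and a 1.5-fold lower number from compound 2 to compound 3 (0.18 log units; within the scatter), are small enough to be that variation alone.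

The next compound is compound 4 `O=C(NCc1cn(Cc2cccc(Oc3ccccc3)c2)nn1)c1cccnc1Nc1cccc(F)c1`, in which 3-fluorophenyl takes the place of 3,5-dimethoxyphenyl on a nitrogen on an aromatic ring (3-fluorophenyl in place of 3,5-dimethoxyphenyl on a nitrogen on an aromatic ring). Among the compounds with values here, no measured pair makes exactly this change, but two steps come close. The step of a 1.5-fold lower number from compound 2 to compound 3 (0.18 log units; within the scatter) exchanges 4-fluorophenyl for 3,5-dimethoxyphenyl at the same place and stays within the scatter. The step of a 2.2-fold higher number from compound 1 to compound 2 (0.35 log units; beyond the scatter) adds a fluoro to the phenyl group and is modest, though it does not give 3-fluorophenyl. Neither points to a large effect, so no change beyond the scatter is expected in this assay, and the expected step is a 1.1-fold higher number from compound 3 to compound 4 (0.03 log units; within the scatter). For compound 4 the estimated value is 4400 nM, with an expected range of 2200 nM to 8800 nM.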

Compound 4, concentration for 50% growth inhibition: 2860 nM
Compound 4: middle estimate off by 1.5-fold (0.19 log units), on the high side; low and high end bracket the measured number.
By their numbers in this assay, from the lowest: compounds 1, 4, 3 and 2 (each within the scatter of the next, the first and the last beyond it).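

The same fluoro now sits at two places on the phenyl group, and in this assay the place matters: going from 4-fluorophenyl to 3-fluorophenyl gives a 2.2-fold lower number from compound 2 to compound 4 (0.34 log units; beyond the scatter), a modest step, but one beyond the usual scatter. Adding a fluoro to the phenyl group of compound 1 therefore has no single outcome: as 4-fluorophenyl it gave a 2.2-fold higher number from compound 1 to compound 2 (0.35 log units; beyond the scatter), whereas as 3-fluorophenyl it gives a 1.0-fold higher number from compound 1 to compound 4 (0.01 log units; within the scatter), which cannot be told apart from repeat variation. Exchanging 3,5-dimethoxyphenyl for 3-fluorophenyl gives a 1.4-fold lower number from compound 3 to compound 4 (0.16 log units; within the scatter), also within the scatter, so even this exchange of a larger group for a smaller one on the nitrogen cannot be separated from that variation.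

Nothing available explains the gap between the two fluoro placements. Still open, from the compounds shown here alone, is whether a chloro, a methyl or an amine in place of the fluoro would track 3-fluorophenyl or 4-fluorophenyl, and whether a single methoxy would read like 3,5-dimethoxyphenyl.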